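The compounds below may be only part of what the source reports. "The series", "measured", "known", "first", "only" and "open" are said of these compounds alone.

Compound 1 `N#C[C@@]1(NC(=O)[C@@H](CC(=O)N2CCOCC2)CC2CCCCC2)CCN(C2CCCC2)C1` has no number of its own in an assay on isolated protein for inhibition of cathepsin S (Homo sapiens); on this read-out higher numbers stand for weaker binding and lower numbers for tighter binding; for compound 1 the outcome recorded is "not determined" (no result reported). Two measured relatives share the same acyl half but carry an open chain where compound 1 has its ring. Compound 2 `N#C[C@H](CCc1ccccc1)NC(=O)[C@@H](CC(=O)N1CCOCC1)CC1CCCCC1` gives 25 nM in this assay, and compound 3 `N#C[C@H](COCc1ccccc1)NC(=O)[C@@H](CC(=O)N1CCOCC1)CC1CCCCC1` gives 4.39 nM in this assay. For the measured compounds named here, the one measured step, a 5.7-fold lower number from compound 2 to compound 3 (0.76 log units; beyond the scatter), comes from benzyloxy in place of benzyl on a saturated chain carbon, two bonds along the chain from an amide-type nitrogen and a triple-bonded carbon; it touches a different part of the molecule from the change studied here.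

Compound 4 `N#C[C@@]1(NC(=O)[C@@H](CC(=O)N2CCOCC2)CC2CCCCC2)CCN(C2CCCCC2)C1` differs from compound 1 only by cyclohexyl in place of cyclopentyl on an amine nitrogen in a ring. Going by the values given here, no measured step concerns any change on that amine nitrogen in a ring, so the size and direction of the step from compound 1 to compound 4 cannot be read from the data. The open-chain pair sets the only anchor for the series, since compound 2 gives 25 nM and compound 3 gives 4.39 nM. On that basis compound 4 is expected to land near 20 nM, somewhere between 3 nM and 150 nM.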

Compound 4, dissociation constant: 17.8 nM
For compound 4 the middle estimate is 1.1-fold (0.05 log units) above the measured one; low and high end bracket the measured number.
By their numbers in this assay, from the lowest: compound 3; then compounds 4 and 2 (each within the scatter of the next).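

In this assay, for the compounds shown here, compound 1 stands as "not determined" (no result reported) and compound 4 gives 17.8 nM so no step between compound 1 and compound 4 can be read. As far as these compounds go, whether cyclohexyl or cyclopentyl on the amine nitrogen in a ring goes with tighter binding stays open. Nothing at hand offers an explanation for the value of compound 4.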